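The source may report more compounds than this note shows. Statements on the series, on what has been measured and on what is new or still open speak of the compounds shown alone.

Of the compounds shown here, two built on one shared core have been tested in a functional assay on MCF7 cells (Homo sapiens) for inhibition, read by MTT assay, with a stated time of 72 h; on this read-out higher numbers stand for weaker inhibition and lower numbers for stronger inhibition. Compound 1, `C#CCSc1nc(Nc2cccc(Cl)c2)c(C#N)c(-c2ccccc2)n1`, gives > 128000 nM in this assay, and that entry is a limit rather than a number. It marks (the limit of > 128000 nM in this assay, at which 1 of the 2 values shown sits). Compound 2, `N#Cc1c(Nc2cccc(C(F)(F)F)c2)nc(SCc2cn(Cc3ccccc3Cl)nn2)nc1-c1ccccc1`, gives 12600 nM in this assay. Among the values shown, compound 2 holds the only actual number; the one other entry is a limit. Compound 3, `N#Cc1c(Nc2ccc(Cl)cc2)nc(SCc2cn(Cc3ccccc3Cl)nn2)nc1-c1ccccc1`, has not yet been measured. It differs from compound 2 in one place: 4-chlorophenyl in place of 3-(trifluoromethyl)phenyl on a nitrogen on an aromatic ring. Going by the values given here, no measured pair shows how such a swap moves the read-out, so the expected step from compound 2 to compound 3 is small, a 1.2-fold higher number from compound 2 to compound 3 (0.08 log units; within the scatter), and may fall in either direction within the usual scatter. Compound 3 is therefore estimated to give about 15000 nM in this assay, with a range from 5000 nM to 45000 nM.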

Compound 3, half-maximal inhibitory concentration: 6520 nM
Compound 3: middle estimate off by 2.3-fold (0.36 log units), on the high side, and the stated range covers the measured number.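

Swapping 3-(trifluoromethyl)phenyl for 4-chlorophenyl on the nitrogen gives a 1.9-fold lower number from compound 2 to compound 3 (0.29 log units; within the scatter) in this assay, the first step in this set between two compounds that differ in one place. At this position, then, these two substituted phenyl rings cannot be told apart from the repeat-to-repeat noise of the measurement, although they carry different substituents. Nothing measured here explains why the two groups give values this close.

Going by these compounds, the result speaks only for this pair, so it remains open whether the nitrogen would accept a group of a different kind, such as an unsubstituted phenyl ring, a pyridine ring or a short alkyl chain. On these data alone, it is also open whether a phenyl ring carrying an amine or a carboxylic acid would give a value that stands clear of the scatter.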